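Rearranging the Bicyclic Heteroaryl on the Amide Carbonyl

A few compounds are considered here, and "the series" means these few. Any claim that something is new, unique, unknown or untested is made for them only; others in the source may bear on it.

Compound 2 `O=C(NCc1ccc(S(=O)(=O)c2ccccc2)cc1)c1ccc2nncn2c1` stands at the bottom of the two measured compounds on the numbers shown. In a functional assay on A2780 cells (Homo sapiens) for inhibition, read by sulforhodamine B assay, with a stated time of 72 h (on this read-out higher numbers stand for weaker inhibition and lower numbers for stronger inhibition), compound 2 gives > 10000 nM, which is a limit of the assay and not a number. Compound 1 `O=C(NCc1ccc(S(=O)(=O)c2ccccc2)cc1)c1nc2cnccc2[nH]1` in this assay gives 5400 nM. Among the measured compounds shown here, the single measured step shows an at least 1.8-fold higher number from compound 1 to compound 2 (0.26 log units; that floor lies within the scatter); its true size stays open because the limit of > 10000 nM in this assay, at which 1 of the 2 values shown sits, caps the second value.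

Compound 3 `O=C(NCc1ccc(S(=O)(=O)c2ccccc2)cc1)c1cn2ccnc2cn1` differs from compound 2 by a group of 9 heavy atoms (6 carbon, 3 nitrogen; one five-membered aromatic ring with 2 hetero atoms, one six-membered aromatic ring with 2 hetero atoms) in place of a group of 9 heavy atoms (6 carbon, 3 nitrogen; one five-membered aromatic ring with 3 hetero atoms, one six-membered aromatic ring with 1 hetero atom), on a carbonyl carbon. For the measured compounds named here, that change sits at the same carbonyl carbon as the measured step, but the measured step is only a floor within the scatter, and nothing among the measured compounds tells whether moving the hetero atom from the five-membered ring into the six-membered ring helps or hurts. The step from compound 2 to compound 3 is therefore expected to be a step that the limit leaves unreadable from compound 2 to compound 3, no more than the scatter, and most likely to end again at the limit. For compound 3 the estimated value is 12000 nM, with a range from 4000 nM to 40000 nM.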

Compound 3, half-maximal inhibitory concentration: > 10000 nM
Compound 3: a limit, no number (the forecaster's own chance of this, stated with the estimate: 65%); the middle value lies beyond the limit too.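

In this assay compound 3, a second rearrangement of the same atoms on the carbonyl carbon, gives > 10000 nM, which is a limit of the assay and not a number. Among the compounds shown here, the one readable comparison is an at least 1.8-fold higher number from compound 1 to compound 3 (0.26 log units; that floor lies within the scatter), so this new arrangement, with one five-membered aromatic ring with 2 hetero atoms and one six-membered aromatic ring with 2 hetero atoms, yields the same kind of floor as the earlier step and no measured size. The step between the two rearranged groups cannot be read, and the series gains no number at this position, because two compounds now end at the same ceiling: the limit of > 10000 nM in this assay, at which 2 of the 3 values shown sit.

As far as these compounds go, whether either rearranged group truly differs from the group in compound 1 by more than the scatter stays open, and so does any order between compound 2 and compound 3. Also open, from the compounds shown here alone, is what an amine or a carboxylic acid on the group at the carbonyl carbon would do to the value in this assay, and whether any such group would bring a compound back within the measurable range.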